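The source may report more compounds than this note shows. Statements on the series, on what has been measured and on what is new or still open speak of the compounds shown alone.

Compound 1 `COc1ccccc1-c1nnc(-c2ccc(C(=O)N/N=C/c3ccccc3[N+](=O)[O-])cc2)o1` is the reference point of this account. Going by the values given here, in an ADME assay on THP-1 cells (Homo sapiens) for cytotoxicity (on this read-out higher numbers stand for weaker inhibition and lower numbers for stronger inhibition), compound 1 gives 161000 nM, the lowest of the two numbers known so far. Among the compounds with values here, its only measured neighbour, compound 2 `COc1ccccc1-c1nnc(-c2ccc(C(=O)N/N=C/c3ccc(F)cc3)cc2)o1`, gives 427000 nM in this assay, and the two are joined by the step of a 2.7-fold higher number from compound 1 to compound 2 (0.42 log units; beyond the scatter). Compound 3 `COc1ccccc1-c1nnc(-c2ccc(C(=O)N/N=C/c3ccc(O)cc3)cc2)o1` has not yet been measured in this assay. It differs from compound 1 in a single place: 4-hydroxyphenyl in place of 2-nitrophenyl on a carbon with a double bond to nitrogen. Within the data shown here, the one comparison that bears on this change is the step from compound 1 to compound 2, which likewise replaced 2-nitrophenyl on a carbon with a double bond to nitrogen, and that step carried the number modestly upward, beyond the scatter. Among the measured compounds shown here, the entering groups in compound 2 and compound 3 are not the same, so the match is imperfect, but the direction is the only guide available. Compound 3 is therefore expected to show a somewhat higher number than compound 1, an estimated step of a 1.9-fold higher number from compound 1 to compound 3 (0.27 log units; within the scatter). The estimate for compound 3 is 300000 nM, with a range from 120000 nM to 750000 nM.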

Compound 3, half-maximal inhibitory concentration: 261000 nM
Estimate against measurement, compound 3: 1.1-fold (0.06 log units) above; low and high end bracket the measured number.
By their numbers in this assay, from the lowest: compounds 1, 3 and 2 (each within the scatter of the next, the first and the last beyond it).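

In this assay, 4-hydroxyphenyl in place of 2-nitrophenyl on the carbon with a double bond to nitrogen gives a 1.6-fold higher number from compound 1 to compound 3 (0.21 log units; within the scatter) and so, unlike the change to 4-fluorophenyl, cannot be told apart from compound 1. Hydroxy in place of fluoro on an aromatic carbon gives a 1.6-fold lower number from compound 2 to compound 3 (0.21 log units; within the scatter) and cannot be told apart from compound 2 either, so the one gap beyond the scatter at this position, a 2.7-fold higher number from compound 1 to compound 2 (0.42 log units; beyond the scatter), now has compound 3 lying within the scatter of both of its ends. The result therefore adds a group that carries a hydrogen-bond donor at this place without showing any separate effect of that donor, and nothing available explains why these groups give the numbers they do.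

The compounds shown leave open whether a 4-aminophenyl or a 4-carboxyphenyl group at this place would stand beyond the scatter from compound 1. They also leave open whether the lowest number belongs to the nitro group itself or to where it sits, a question that a 4-nitrophenyl group on the same carbon would address directly.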